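Chain extension on the shared core: compound 1 to compound 4

The source may hold more compounds than are shown below. What is called first, only, known or untested is meant among the compounds shown, and "the series" means these compounds.

Values in a functional assay on the whole organism with Mus musculus as the target (a higher number here means a larger maximal response, a lower number a smaller maximal response), for the measured compounds:
compound 1 `CCn1c(=O)n(C2OC(CO)[C@@H](O)[C@H]2O)c2nc(N)nc(O)c21`: 82%
compound 2 `C=CCn1c(=S)n([C@@H]2O[C@H](CO)[C@H]3OC(C)(C)O[C@H]32)c2nc(N)nc(O)c21`: 9%
compound 3 `C=CCn1c(=O)n(C2C[C@H](O)C(CO)O2)c2nc(N)nc(O)c21`: 131%

Compound 1 holds the second highest of the three maximal responses. Compound 3 lies above it, beyond the scatter, and compound 2 lies well below it, also beyond the scatter; both of these compounds differ from compound 1 in more than one place, so their values are noted only as they stand, without a single-point comparison.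

Compound 4 `CCCCCCn1c(=O)n(C2OC(CO)[C@@H](O)[C@H]2O)c2nc(N)nc(O)c21` is not yet measured. It differs from compound 1 by butyl in place of hydrogen on a saturated chain carbon, two bonds along the chain from an aromatic nitrogen. Among the measured compounds shown here, no measured pair in this set isolates such a change, so the direction of the step rests on expectation alone. The step from compound 1 to compound 4 in this assay, a number 14 percentage points lower from compound 1 to compound 4 (beyond the scatter), is expected to be small and downward, or none beyond the scatter. Compound 4 is therefore estimated to give 68% in this assay, within a range from 30% to 105%.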

Compound 4, largest response reached (reported as maximal response), in percent of the reference or control that the assay uses: 11%
The estimate for compound 4 lay 57 percentage points above the measured number; measured number below the stated range.
By their numbers in this assay, from the lowest: compounds 2 and 4 (each within the scatter of the next); then compound 1; then compound 3.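

Butyl in place of hydrogen on a saturated chain carbon, two bonds along the chain from an aromatic nitrogen, gives in this assay a number 71 percentage points lower from compound 1 to compound 4 (beyond the scatter) and is the first single-point reading in this series. This position therefore does not accept the change from ethyl to hexyl without loss, and the size of the step marks the chain here as a strong control on maximal response in the core of compound 1. Nothing on hand accounts for this fall, so it stands as an observation without a stated cause.

As far as these compounds go, with only ethyl and hexyl on this core, the shape of the chain-length relation remains unknown, including whether the response falls gradually through propyl, butyl and pentyl or abruptly at one length. Also open, from the compounds shown here alone, is whether a branched chain such as isopropyl, or a hexyl chain carrying a hydroxyl group or an amine, keeps the response of compound 1.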